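A few compounds are considered here, and "the series" means these few. Any claim that something is new, unique, unknown or untested is made for them only; others in the source may bear on it.

Compound 1 `C=C1CC[C@@H]2[C@](C)(COC(C)=O)[C@H](OC(C)=O)CC[C@@]2(C)[C@H]1CC(Nc1ccc(S(=O)(=O)Nc2nccc(C)n2)cc1)C1=CCOC1=O` and compound 2 `C=C1CC[C@@H]2[C@](C)(COC(C)=O)[C@H](OC(C)=O)CC[C@@]2(C)[C@H]1CC(Nc1ccc(S(=O)(=O)Nc2nccs2)cc1)C1=CCOC1=O` share one core and differ only in the ring carried on the sulfonamide nitrogen. In a functional assay on NCI-H522 cells (Homo sapiens) for inhibition, read by sulforhodamine B assay, with a stated time of 48 h (a lower number here means a stronger inhibitor of growth, a higher number a weaker inhibitor of growth), compound 1 gives 1260 nM. In this assay compound 2 gives 1720 nM, a number that sits within the usual scatter of the number for compound 1, so neither can be called the stronger. Going by the values given here, the step of a 1.4-fold higher number from compound 1 to compound 2 (0.14 log units; within the scatter) is the only measured change at that position. Compound 3 `C=C1CC[C@@H]2[C@](C)(COC(C)=O)[C@H](OC(C)=O)CC[C@@]2(C)[C@H]1CC(Nc1ccc(S(=O)(=O)Nc2ncccn2)cc1)C1=CCOC1=O` arises from compound 2 by the change (pyrimidin-2-yl in place of 1,3-thiazol-2-yl on a sulfonamide nitrogen). Among the compounds with values here, the one measured step that bears on this, the swap of rings on that nitrogen from compound 1 to compound 2, stayed within the scatter, and the ring entering compound 3 is the ring of compound 1 lacking its methyl. Compound 3 is therefore expected to show a step of a 1.2-fold lower number from compound 2 to compound 3 (0.09 log units; within the scatter), nothing beyond the scatter. The estimated value of compound 3 is 1400 nM, with a range from 700 nM to 2800 nM.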

Compound 3, concentration for 50% growth inhibition: 490 nM
Compound 3: middle estimate off by 2.9-fold (0.46 log units), on the high side; the measured number lies below the stated range.
By their numbers in this assay, from the lowest: compound 3; then compounds 1 and 2 (each within the scatter of the next).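

In this assay the ring on the sulfonamide nitrogen turns out to matter: pyrimidin-2-yl in place of 1,3-thiazol-2-yl gives a 3.5-fold lower number from compound 2 to compound 3 (0.55 log units; beyond the scatter) and so moves beyond the scatter, which the earlier swap of rings did not do. Even a single methyl counts, as hydrogen in place of methyl on an aromatic carbon gives a 2.6-fold lower number from compound 1 to compound 3 (0.41 log units; beyond the scatter) and makes compound 3 the strongest growth inhibitor of the three. Nothing available here explains these differences.

The compounds shown leave open whether a methoxy group or an amine in place of that methyl would keep the lower number, and whether a plain phenyl ring on the sulfonamide nitrogen would do as well. They also leave open whether the same order holds in other cell lines.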